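Urea series: methyl on the phenolic oxygen

This account rests on a few compounds, and the source may have more. Where it says the series, first, only, none or still open, it means among the compounds named here.

Compound 2 `O=C(Nc1cccc(-n2cc(-c3ccncc3)c(-c3cc(O)cc(Cl)c3)n2)c1)Nc1ccc(Cl)c(Cl)c1` stands at the low end of the two numbers available: in a functional assay on SK-MEL-28 cells (Homo sapiens) for inhibition, read by sulforhodamine B assay, with a stated time of 48 h, tested at 10 uM (a higher number here means a weaker effect of the compound at the concentration tested, a lower number a stronger effect), compound 2 gives -50.9%. Compound 1 `COc1cc(Cl)cc(-c2nn(-c3cccc(NC(=O)c4cccc(C(F)(F)F)c4)c3)cc2-c2ccncc2)c1`, which carries a methoxy group and an amide linker rather than a urea, gives 70.4% in this assay, a reading far higher than that of compound 2 and beyond the scatter. For the measured compounds named here, the two compounds differ in more than one place, so no single step between them can be read.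

Compound 3 `COc1cc(Cl)cc(-c2nn(-c3cccc(NC(=O)Nc4ccc(Cl)c(Cl)c4)c3)cc2-c2ccncc2)c1` keeps the urea of compound 2 and changes only the phenol. The difference is methyl in place of hydrogen on an oxygen on an aromatic ring; one bond further out it reads hydroxy to methoxy, 3-chloro-5-hydroxyphenyl to 3-chloro-5-methoxyphenyl. Going by the values given here, no measured pair isolates this change, and compound 1, which holds the methoxy group, also holds a different linker. The expectation is a step toward weaker effect in this assay, of moderate size, a number 35.9 percentage points higher from compound 2 to compound 3 (beyond the scatter), though the urea is expected to keep compound 3 well below compound 1. Compound 3 is therefore estimated at -15%, with a range from -55% to 35%.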

Compound 3, a percentage reported as activity, at one concentration (the size of the read-out at that concentration, not a potency): 23.2%
The estimate for compound 3 lay 38.2 percentage points below the measured number, and the stated range covers the measured number.
By their numbers in this assay, from the lowest: compound 2; then compound 3; then compound 1.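

For the compounds shown here, with the urea held fixed, methyl in place of hydrogen on an oxygen on an aromatic ring gives a number 74.1 percentage points higher from compound 2 to compound 3 (beyond the scatter) in this assay and takes the read-out from a negative to a positive number, which makes this the first single-place reading at this oxygen and shows that the free hydroxy and the methoxy are not interchangeable here. With the methoxy held fixed, (3,4-dichlorophenyl)amino in place of 3-(trifluoromethyl)phenyl on a carbonyl carbon gives a number 47.2 percentage points lower from compound 1 to compound 3 (beyond the scatter) in this assay, so the number also responds to this second place and compound 3 sits between the other two, each reached by a single change. No measurement at hand bears on why either change moves the number.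

Going by these compounds, it remains open whether the step at the oxygen is the same size when the 3-(trifluoromethyl)phenyl amide of compound 1 stands in place of the urea, as a single pair at one concentration cannot say how far it carries. Also open, on these data alone, is how this position reads with an ethyl group or a longer chain on the oxygen, or with an amine in place of the hydroxy.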